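Phenoxy to methoxy on the aryl group in cytotoxicity

This account rests on a few compounds, and the source may have more. Where it says the series, first, only, none or still open, it means among the compounds named here.

Three analogues of the shared core have been measured in a functional assay on SK-MEL-5 cells (Homo sapiens) for cytotoxicity, read by sulforhodamine B assay, with a stated time of 48 h; a higher number here means a weaker inhibitor of growth, a lower number a stronger inhibitor of growth. Compound 1 `CC1=C(C(=O)Nc2ccc(F)c(Cl)c2)C(c2ccccc2Cl)NC(=S)N1` gives 12300 nM. Compound 2 `CC1=C(C(=O)Nc2ccc(F)c(Cl)c2)C(c2cccc(Oc3ccccc3)c2)NC(=S)N1` gives 8910 nM. Compound 3 `CC1=C(C(=O)Nc2ccc(Cl)c(Cl)c2)C(c2cccc(Oc3ccccc3)c2)NC(=S)N1` gives 7940 nM. In this assay compound 2 stands second highest of the three numbers; its nearest neighbour is compound 3, its furthest is compound 1, and both gaps lie within the scatter, so no order among the three can be read.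

Compound 4 `COc1cccc(C2NC(=S)NC(C)=C2C(=O)Nc2ccc(F)c(Cl)c2)c1` differs from compound 2 by methyl in place of phenyl on an oxygen on an aromatic ring. Within the data shown here, the only step between measured compounds that differ in one place is a 1.1-fold lower number from compound 2 to compound 3 (0.05 log units; within the scatter), which concerns the anilide halogen and does not touch the ether. Compound 1 and compound 2 differ at the aryl group in more than one place, and their two values are within the scatter of each other. Among the measured compounds shown here, no measured step therefore bears directly on the change from phenoxy to methoxy, and the three numbers seen span less than the scatter.

For compound 4 the step is expected as a 1.2-fold higher number from compound 2 to compound 4 (0.09 log units; within the scatter) in this assay, that is no change beyond the scatter. Compound 4 is estimated at 11000 nM, with a range from 4000 nM to 30000 nM.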

Compound 4, concentration for 50% growth inhibition: 13200 nM
Compound 4: the middle estimate sits 1.2-fold (0.08 log units) below what was measured, within the range that was stated.
By their numbers in this assay, from the lowest: compounds 3, 2, 1 and 4 (each within the scatter of the next).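

Among these compounds, at the oxygen on the aromatic ring, the change from phenoxy to methoxy in this assay gives a 1.5-fold higher number from compound 2 to compound 4 (0.17 log units; within the scatter) and is the first measured step at this position: a phenyl of 6 heavy atoms, with its six-membered aromatic ring, gives way to a methyl of 1 heavy atom without a change beyond the scatter. On the saturated ring carbon, 3-methoxyphenyl in place of 2-chlorophenyl gives a 1.1-fold higher number from compound 1 to compound 4 (0.03 log units; within the scatter) and so likewise shows no change beyond the scatter in this series. No measurement shown here accounts for either step, so the two results stand as observations only.

Still open, going by these compounds, is whether any replacement at this oxygen gives a step beyond the scatter, for example a hydrogen in place of the phenyl, a longer chain such as n-butyl, or a chain ending in an amine or a carboxylic acid. Also open, on these data alone, is whether the change from phenoxy to methoxy reads the same with the anilide of compound 3, which carries chloro in place of fluoro.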